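Piperidine Ureas: Ethyl to Oxanyl on the Amide Carbonyl

The compounds below may be only part of what the source reports. "The series", "measured", "known", "first", "only" and "open" are said of these compounds alone.

The measured compounds so far:

Compound 1, `CC[C@H](C)C(=O)N1CCC(NC(=O)Nc2ccc(OC(F)(F)F)c(Br)c2)CC1`, gives 0.58 ug/mL in a physicochemical assay for solubility, read by mass spectrometry, in phosphate buffer, with a stated time of 24 h, at pH 7.4; a lower number here means a less soluble compound, a higher number a more soluble compound.
Compound 2, `CCC(=O)N1CCC(NC(=O)Nc2ccc(C(F)(F)F)c(F)c2)CC1`, gives 3.9 ug/mL in this assay.

Among the compounds with values here, of the two numbers in hand, compound 2 holds the higher one; its only neighbour, compound 1, lies below it by a gap beyond the scatter. Within the data shown here, since compound 1 and compound 2 differ in more than one place, their pair offers no single step to read.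

The next compound, compound 3, `O=C(Nc1ccc(C(F)(F)F)c(F)c1)NC1CCN(C(=O)C2CCOCC2)CC1`, is not yet measured. It differs from compound 2 at one place: oxan-4-yl in place of ethyl on a carbonyl carbon. Among the measured compounds shown here, no measured pair shows this change, so its effect is unknown here. In this assay compound 3 is expected to move from compound 2 by a 2.1-fold higher number from compound 2 to compound 3 (0.31 log units; beyond the scatter), a modest rise rather than a large one. The estimate for compound 3 is 8 ug/mL, with a range from 2.5 ug/mL to 25 ug/mL.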

Compound 3, solubility: 42 ug/mL
Compound 3: middle estimate off by 5.3-fold (0.72 log units), on the low side; the measured number lies above the stated range.
By their numbers in this assay, from the lowest: compound 1; then compound 2; then compound 3.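

Within the data shown here, exchanging ethyl for oxan-4-yl on a carbonyl carbon gives an 11-fold higher number from compound 2 to compound 3 (1.03 log units; beyond the scatter) in this assay, the first step in this set that can be read at a single place, and it shows that this position can carry a large change in the read-out. The entering group brings one six-membered non-aromatic ring with 1 hetero atom and 1 hydrogen-bond acceptor, and neither group has a net charge, so the large rise comes with no charge entering at this position. Nothing measured here accounts for the size of this rise.

Still open, as far as these compounds go, is how much of the step depends on the ring oxygen, a question that cyclohexyl on the same carbonyl carbon would address. Also open, from the compounds shown here alone, is whether the same change would give a comparable step on the core of compound 1.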